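Notes on the series: from compound 2 to compound 3

The compounds below may be only part of what the source reports. "The series", "measured", "known", "first", "only" and "open" are said of these compounds alone.

Compound 2 `CC(=O)c1cc(CC(C)O)c(OCCCCC#N)cc1O` stands lowest of the two measured numbers: in an assay on isolated protein for binding affinity to leukotriene B4 receptor 1 (Homo sapiens), tested at 1 uM (on this read-out lower numbers stand for less inhibition and higher numbers for more inhibition at the one concentration tested (going by the name of the read-out)), compound 2 gives 6%, while compound 1 `CC(=O)c1cc(CC2CO2)c(OCCCCC#N)cc1O` gives 24%. Going by the values given here, the only measured step, a number 18 percentage points lower from compound 1 to compound 2 (beyond the scatter), covers that pair and is the single guide available. Compound 3 `C=CCc1cc(C(C)=O)c(O)cc1OCCCCC#N` is not yet measured; it differs from compound 2 as vinyl in place of 1-hydroxyethyl on a saturated chain carbon bound to an aromatic carbon. The measured step exchanged oxiran-2-yl for 1-hydroxyethyl on the same saturated chain carbon bound to an aromatic carbon and lowered the number; vinyl is a different group again, so that step supports only a loose analogy, and the uncertainty is wide. The step expected is a number 8 percentage points higher from compound 2 to compound 3 (within the scatter), a modest rise back toward the number of compound 1. Compound 3 is therefore estimated at 14% in this assay, with a range from 0% to 30%.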

Compound 3, a percentage reported as inhibition, at one concentration (the size of the read-out at that concentration, not a potency): 57%
Beside the measured number, compound 3's estimate is 43 percentage points below it; measured number above the stated range.
By their numbers in this assay, from the lowest: compound 2; then compound 1; then compound 3.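

At this saturated chain carbon bound to an aromatic carbon, in this assay, vinyl stands above both earlier groups, with a number 51 percentage points higher from compound 2 to compound 3 (beyond the scatter) and a number 33 percentage points higher from compound 1 to compound 3 (beyond the scatter) as the two steps. Going by these compounds alone, compound 1 and compound 2 showed only that the number moves when oxiran-2-yl gives way to 1-hydroxyethyl, whereas these steps show that the group at this place can also carry the number well above either of them, and that a group with no oxygen gives the highest of the three numbers. Nothing at hand gives a measured reason for this rise.

On these data alone, whether the double bond of vinyl is needed stays open, since ethyl at the same place would separate it from the mere absence of oxygen. An amine such as 1-aminoethyl would show whether 1-hydroxyethyl's low number extends to other groups of that shape.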